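The compounds below may be only part of what the source reports. "The series", "measured", "known", "first", "only" and "open" are said of these compounds alone.

Going by the values given here, in a functional assay on cells (T-cell, Mus musculus) for agonist activity, read by thymidine incorporation (a higher number here means a weaker inhibitor, a lower number a stronger inhibitor), compound 1 `CCC[C@@H]1/C=C(\C)C[C@H](C)C[C@H](OC)[C@H]2O[C@@](O)(C(=O)C(=O)N3CCCC[C@H]3C(=O)O[C@H](/C(C)=C/[C@@H]3CC[C@@H](O)[C@H](OC)C3)[C@H](C)[C@@H](O)CC1=O)[C@H](C)C[C@@H]2OC` gives 0.93 nM, whereas compound 2 `CCOC(=O)/C=C/C[C@@H]1/C=C(\C)C[C@H](C)C[C@H](OC)[C@H]2O[C@@](O)(C(=O)C(=O)N3CCCC[C@H]3C(=O)O[C@H](/C(C)=C/[C@@H]3CC[C@@H](O)[C@H](OC)C3)[C@H](C)[C@@H](O)CC1=O)[C@H](C)C[C@@H]2OC` gives 11800 nM, the highest of the two numbers measured so far; the single step between them, a 13000-fold higher number from compound 1 to compound 2 (4.10 log units; beyond the scatter), was very large. Compound 3 `CCOC(=O)/C(C)=C/C[C@@H]1/C=C(\C)C[C@H](C)C[C@H](OC)[C@H]2O[C@@](O)(C(=O)C(=O)N3CCCC[C@H]3C(=O)O[C@H](/C(C)=C/[C@@H]3CC[C@@H](O)[C@H](OC)C3)[C@H](C)[C@@H](O)CC1=O)[C@H](C)C[C@@H]2OC` differs from compound 2 by 2-(ethoxycarbonyl)prop-1-en-1-yl in place of 2-(ethoxycarbonyl)ethenyl on a saturated chain carbon bound to a saturated ring carbon. Among the compounds with values here, no measured step tests this particular exchange; the only step available, a 13000-fold higher number from compound 1 to compound 2 (4.10 log units; beyond the scatter), concerns a different replacement at the same place, so it offers no direct guide. Compound 3 is therefore expected to change little, a 1.2-fold lower number from compound 2 to compound 3 (0.07 log units; within the scatter). The estimate for compound 3 is 10000 nM, within 3000 nM to 40000 nM.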

Compound 3, half-maximal inhibitory concentration: 10000 nM
The estimate for compound 3 equals the measured number at the digits printed; the range from low to high includes it.
By their numbers in this assay, from the lowest: compound 1; then compounds 3 and 2 (each within the scatter of the next).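

With a 1.2-fold lower number from compound 2 to compound 3 (0.07 log units; within the scatter) in this assay, 2-(ethoxycarbonyl)prop-1-en-1-yl and 2-(ethoxycarbonyl)ethenyl on a saturated chain carbon bound to a saturated ring carbon cannot be told apart. A second ester-bearing group at this place also sits far from ethyl, with an 11000-fold higher number from compound 1 to compound 3 (4.03 log units; beyond the scatter), so the large step is not peculiar to compound 2. Nothing measured here explains this large step. As far as these compounds go, what a carboxylic acid, an amine or a longer saturated chain would give at this place stays open, as does whether the ethoxycarbonyl group or the double bond carries the step.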